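A few compounds are considered here, and "the series" means these few. Any claim that something is new, unique, unknown or untested is made for them only; others in the source may bear on it.

In an assay on Sf21 cells for inhibition of MAP kinase-interacting serine/threonine-protein kinase 2 (Homo sapiens), read by luminescence and ADP-Glo, with stated times of 10 min and 40 min, tested at 500 nM (on this read-out lower numbers stand for less inhibition and higher numbers for more inhibition at the one concentration tested (going by the name of the read-out)), the measured compounds gave these values: compound 1 `O=C(c1ccc(-c2ccc3ncc(-c4ccc5cnccc5c4)n3c2)cc1)N1CCC(N2CCCCC2)CC1` gives 74.7%; compound 2 `O=C(c1ccc(-c2ccc3ncc(-c4ccc5ncccc5c4)n3c2)cc1)N1CCC(N2CCCCC2)CC1` gives 2.41%; compound 3 `O=C(c1ccc(-c2ccc3ncc(-c4cnc5ccccc5c4)n3c2)cc1)N1CCOCC1` gives 21%.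

Among the three, compound 3 stands second highest, above compound 2 and well below compound 1, both gaps beyond the scatter. Compound 4 `O=C(c1ccc(-c2ccc3ncc(-c4cnc5ccccc5c4)n3c2)cc1)N1CCC(N2CCCCC2)CC1` differs from compound 3 in one place: 4-(piperidin-1-yl)piperidin-1-yl in place of morpholin-4-yl on a carbonyl carbon. Going by the values given here, no measured step covers this change. Among the compounds with values here, the only step recorded, a number 72.3 percentage points lower from compound 1 to compound 2 (beyond the scatter), concerns the aromatic group instead, and compounds 1 and 2 both already carry 4-(piperidin-1-yl)piperidin-1-yl, so no pair compares it against morpholin-4-yl. The expected step in this assay is therefore none beyond the scatter, a number 4 percentage points higher from compound 3 to compound 4 (within the scatter), with wide uncertainty. Compound 4 is estimated at 25%, in a range from 5% to 50%.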

Compound 4, a percentage reported as inhibition, at one concentration (the size of the read-out at that concentration, not a potency): 48.8%
Compound 4: the middle estimate sits 23.8 percentage points below what was measured; measured number inside the range.
By their numbers in this assay, from the lowest: compound 2; then compound 3; then compound 4; then compound 1.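

In this assay, going by these compounds alone, the group on the carbonyl carbon clearly matters, since 4-(piperidin-1-yl)piperidin-1-yl in place of morpholin-4-yl gives a number 27.8 percentage points higher from compound 3 to compound 4 (beyond the scatter) in the first direct comparison of these two groups. With 4-(piperidin-1-yl)piperidin-1-yl held constant, the aromatic group can now be ranked in three forms: quinolin-3-yl gives a number 46.4 percentage points higher from compound 2 to compound 4 (beyond the scatter) against quinolin-6-yl and a number 25.9 percentage points lower from compound 1 to compound 4 (beyond the scatter) against isoquinolin-6-yl, placing it between them. Still open, on these data alone, is how a piperazine or an open-chain amine such as dimethylamino would compare on the carbonyl carbon, and whether isoquinolin-6-yl would stay ahead when paired with morpholin-4-yl. No supporting measurement is available to explain these differences.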